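Quinoline Swap Repeated on a Second Core

This account rests on a few compounds, and the source may have more. Where it says the series, first, only, none or still open, it means among the compounds named here.

Four compounds share one core and are compared in a functional assay on NCI-H1993 cells (Homo sapiens) for inhibition, read by CCK-8 assay, with a stated time of 72 h; a higher number here means a weaker inhibitor, a lower number a stronger inhibitor. Compound 1 `COC(=O)c1ccc(-c2cnc3ncn(C(C)c4cc5cccnc5cc4F)c3n2)cc1F` carries a 3-fluoro-4-(methoxycarbonyl)phenyl group and in this assay compound 1 gives 60.2 nM. Compound 3 `CC(c1cc2cccnc2cc1F)n1cnc2ncc(-c3cnc4ccccc4c3)nc21` keeps the same core but carries quinolin-3-yl instead; in this assay compound 3 gives 109 nM. The change between them is quinolin-3-yl in place of 3-fluoro-4-(methoxycarbonyl)phenyl on an aromatic carbon, and the step it made is a 1.8-fold higher number from compound 1 to compound 3 (0.26 log units; within the scatter).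

Compound 2 `COC(=O)c1ccc(-c2cnc3ncn(C(C)c4ccc5ncccc5c4C)c3n2)cc1F` has a different core, and how it differs from compound 1 is a group of 11 heavy atoms (10 carbon, 1 nitrogen; one six-membered aromatic ring of carbon only, one six-membered aromatic ring with 1 hetero atom) in place of a group of 11 heavy atoms (9 carbon, 1 nitrogen, 1 fluorine; one six-membered aromatic ring of carbon only, one six-membered aromatic ring with 1 hetero atom), on a saturated chain carbon bound to an aromatic nitrogen and a saturated chain carbon. In this assay compound 2 gives "not determined" (no result reported), so no number stands for it. Compound 4 `Cc1c(C(C)n2cnc3ncc(-c4cnc5ccccc5c4)nc32)ccc2ncccc12` is the partner of compound 2 in the same way that compound 3 is the partner of compound 1: the change from compound 2 to compound 4 is quinolin-3-yl in place of 3-fluoro-4-(methoxycarbonyl)phenyl on an aromatic carbon, and it sits at the same place as before, so it is the same change made on a second core.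

Since compound 2 has no number, the step from compound 2 to compound 4 cannot be anchored directly, but it is expected to be of the same size as a 1.8-fold higher number from compound 1 to compound 3 (0.26 log units; within the scatter), that is within the scatter. Compound 4 is expected to give about 120 nM because compound 3 gives 109 nM with the same quinolin-3-yl group. The range for compound 4 is estimated as 40 nM to 400 nM, and it is wide; the effect of the core difference is not measured here.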

Compound 4, half-maximal inhibitory concentration: 450 nM
The estimate for compound 4 lay 3.8-fold (0.57 log units) below the measured number, outside the stated range (above it).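

No new step can be read here: in this assay compound 4 gives 450 nM but compound 2 has no number to set against it, so this pair offers no comparison. Going by these compounds, what the change to quinolin-3-yl does on this second core stays open, as does the effect of the core difference itself. Nothing shown here offers an explanation for the value of compound 4.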